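Methylcarbamoyl in place of pyrazolyl on a shared core

The source may report more compounds than this note shows. Statements on the series, on what has been measured and on what is new or still open speak of the compounds shown alone.

The account begins with compound 1, `c1cc(-c2ccn[nH]2)c2c(c1)C(c1ncc[nH]1)CC2`, a compound tested in a functional assay on CHO cells for agonist activity at Alpha-1A adrenergic receptor (Homo sapiens), read by FLIPR and calcium flux; on this read-out higher numbers stand for larger maximal responses and lower numbers for smaller maximal responses. In this assay compound 1 gives 83%. Among the measured compounds shown here, the only other measured compound, compound 2, `Cc1c(OCC2=NCCN2)ccc(Cl)c1NS(C)(=O)=O`, gives 60% in the same assay. Of these two numbers, compound 1 stands highest; its value lies above that of compound 2 by a gap that goes beyond the scatter of repeated measurements. For the measured compounds named here, no single-point step between measured compounds is available, so how the response of compound 1 answers to a change on its core cannot be read from any measured pair.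

Compound 3, `CNC(=O)c1cccc2c1CCC2c1ncc[nH]1`, has not yet been measured in this assay. It differs from compound 1 in one place: methylcarbamoyl in place of 1H-pyrazol-5-yl on an aromatic carbon. The group that leaves and the group that enters each carry one hydrogen-bond donor and one hydrogen-bond acceptor, but the ring is lost. Without a measured step to lean on, the step from compound 1 to compound 3 is expected to be a modest decrease, a number 13 percentage points lower from compound 1 to compound 3 (beyond the scatter), possibly no larger than the scatter. The estimate for compound 3 in this assay is 70%, with a range from 45% to 95%.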

Compound 3, largest response reached (Emax), in percent of the reference or control that the assay uses: 59%
Compound 3: the middle estimate sits 11 percentage points above what was measured; measured number inside the range.
By their numbers in this assay, from the lowest: compounds 3 and 2 (each within the scatter of the next); then compound 1.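

In this assay, among the compounds shown here, putting methylcarbamoyl in place of 1H-pyrazol-5-yl on this aromatic carbon gives a number 24 percentage points lower from compound 1 to compound 3 (beyond the scatter), the first measured step on the shared core, and it shows that the maximal response at this position depends on which group is attached. For the compounds shown here, the group that leaves and the group that enters have the same counts of hydrogen-bond donors and acceptors, so this match in counts alone did not keep the number at the level of compound 1, while the five-membered aromatic ring of the departing group has no counterpart in the ringless group that enters. No measurement of any other property of these compounds bears on the step, so what lies behind it remains unexplained.

With a single change at this position, the compounds shown cannot separate the absence of the ring from the particular character of the methylcarbamoyl group. A furan ring on the same aromatic carbon would bear on the first of these, whereas a carbamoyl group without the methyl, or a carboxylic acid, would bear on the second.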